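The source may report more compounds than this note shows. Statements on the series, on what has been measured and on what is new or still open speak of the compounds shown alone.

Measured compounds:
compound 1, `OB1OCc2ccc(-n3cc(Sc4cccc(Cl)c4)c4ccccc43)cc21`. In an ADME assay on L929 cells (Mus musculus) for cytotoxicity, read by resazurin assay, with a stated time of 72 h (a lower number here means a stronger inhibitor, a higher number a weaker inhibitor), compound 1 gives > 10 ug/mL, a limit of the assay rather than a number.
compound 2, `OB1OCc2ccc(-n3cc(Sc4ccc5ccccc5c4)c4ccccc43)cc21`. In this assay compound 2 gives > 10 ug/mL, again a limit.
compound 3, `O=C(c1ccc(F)cc1)c1ccn(-c2ccc3c(c2)B(O)OC3)c1`. In this assay compound 3 gives > 10 ug/mL, also a limit.

Compound 3 therefore stands where every measured value sits, at the limit of > 10 ug/mL in this assay, at which 3 of the 3 values shown sit. For the measured compounds named here, the only step between measured compounds, a step that the two limits leave unreadable from compound 1 to compound 2, runs between two limits and gives no readable size.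

Compound 4, `Nc1ccc(C(=O)c2ccn(-c3ccc4c(c3)B(O)OC4)c2)cc1`, differs from compound 3 by amino in place of fluoro on an aromatic carbon. Going by the values given here, no measured step bears on this change, and the one step that exists is unreadable, so nothing in the data points to a move in either direction. The account expects the step that the limit leaves unreadable from compound 3 to compound 4 to lie within the scatter. Compound 4 is estimated at 15 ug/mL in this assay, with a range from 6 ug/mL to 40 ug/mL, most likely reported again as a limit.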

Compound 4, half-maximal inhibitory concentration: 3.9 ug/mL
The estimate for compound 4 lay 3.8-fold (0.59 log units) above the measured number, outside the stated range (below it).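

In this assay, the swap of 4-fluorophenyl to 4-aminophenyl gives an at least 2.5-fold lower number from compound 3 to compound 4 (0.40 log units; beyond the scatter), so this one place, para to a large group, is not indifferent to what it carries. Its size remains a lower bound, since one end of the step is a limit and the true distance could be larger. For the compounds shown here, compound 4 is the only one of the four compounds with a readable number, while the others all rest at a limit: the limit of > 10 ug/mL in this assay, at which 3 of the 4 values shown sit.

The compounds shown leave open whether the shift belongs to the amino group itself or would also come with a hydroxyl, a methoxy or an acetamide at the same place. They also leave open whether an amino group would do the same on the sulfur-linked compound 1 and compound 2.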